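From Heptylcarbonyl to Benzyl on a Shared Core

This account rests on a few compounds, and the source may have more. Where it says the series, first, only, none or still open, it means among the compounds named here.

Of the compounds shown here, three that share the same triazole-bearing core have been measured in an assay on nucleic acid for inhibition of Nucleic Acid, read by fluorescence, tested at 100 uM; on this read-out higher numbers stand for more inhibition at the one concentration tested (going by the name of the read-out) and lower numbers for less inhibition. Compound 1, `CCCCNC(=O)OCC(O)Cn1cc(CN(C)CCC(C)C)nn1`, gives 24% in this assay. Compound 2, `OC1CCCCC1n1cc(CN2CCN(c3ccccc3)CC2)nn1`, gives 47% in this assay. Compound 3, `CCCCCCCC(=O)OCC(O)Cn1cc(CN2CCN(c3ccccc3)CC2)nn1`, gives 26% in this assay. Among these three numbers compound 3 stands second highest: its nearest neighbour is compound 1, whose number lies within the usual scatter of repeated measurements, so the two cannot be told apart, while compound 2 lies beyond the scatter above it.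

The next compound to be tested, compound 4, is `OC(COCc1ccccc1)Cn1cc(CN2CCN(c3ccccc3)CC2)nn1`. It differs from compound 3 in one place: benzyl in place of heptylcarbonyl on an oxygen on a saturated carbon. Cut one bond further out, the same difference reads (heptylcarbonyl)oxy to benzyloxy.

Within the data shown here, no pair of measured compounds differs in exactly this way, so there is no measured step to lean on. The two compounds that carry a substituted oxygen on the saturated chain, compound 1 and compound 3, sit close together, and nothing in the data points to a large move. The expected step from compound 3 to compound 4 is therefore a number 4 percentage points higher from compound 3 to compound 4 (within the scatter), which is no change beyond the scatter. Compound 4 is estimated to give 30% in this assay, with a range from 15% to 50%.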

Compound 4, a percentage reported as inhibition, at one concentration (the size of the read-out at that concentration, not a potency): 37%
Estimate against measurement, compound 4: 7 percentage points below; low and high end bracket the measured number.
By their numbers in this assay, from the lowest: compounds 1 and 3 (each within the scatter of the next); then compounds 4 and 2 (each within the scatter of the next).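

Among these compounds, compound 3 and compound 4 form the only pair here that differs in one place, so they give the first direct reading of this position in this assay: a number 11 percentage points higher from compound 3 to compound 4 (beyond the scatter) is a modest step, but it lies beyond the usual scatter. The group on this oxygen therefore does matter, and an ester-type heptylcarbonyl is not needed to keep the inhibition, since benzyl, with its six-membered aromatic ring and no carbonyl, does at least as well on the shared core. Nothing available explains why the number moves with this swap.

The swap removes a carbonyl and a long open chain while adding an aromatic ring, all in one step, so the compounds shown cannot say which of these changes carries the rise; a benzoyl group or a plain heptyl chain on the same oxygen would begin to separate them. Going by these compounds, whether a ring bearing an amine, a carboxylic acid or a longer link such as phenylethyl would move the number further also stays open.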